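The compounds below may be only part of what the source reports. "The series", "measured", "known", "first", "only" and "open" are said of these compounds alone.

Measured compounds:
- Compound 1 `CC1(C)[C@H]2CC[C@]1(C)N(Cc1cn(-c3ccccc3Br)nn1)C(=O)C2`: 140 nM
- Compound 2 `Cc1ccccc1-n1cc(CN2C(=O)C[C@@H]3CC[C@@]2(C)C3(C)C)nn1`: 150 nM
- Compound 3 `COc1cccc(-n2cc(CN3C(=O)C[C@@H]4CC[C@@]3(C)C4(C)C)nn2)c1`: 280 nM

These values come from a functional assay on OVCAR-3 cells (Homo sapiens) for inhibition, read by MTT assay, with a stated time of 24 h; on this read-out lower numbers stand for stronger inhibition and higher numbers for weaker inhibition. There, compound 3 gives 280 nM, which is within the scatter of the other two: a 2.0-fold higher number from compound 1 to compound 3 (0.30 log units; within the scatter) and a 1.9-fold higher number from compound 2 to compound 3 (0.27 log units; within the scatter).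

Compound 4 `COc1ccc(-n2cc(CN3C(=O)C[C@@H]4CC[C@@]3(C)C4(C)C)nn2)cc1` has 4-methoxyphenyl in place of 3-methoxyphenyl on an aromatic nitrogen.

Going by the values given here, no measured step makes this exact change. The nearest evidence is those two steps, which alter the same aryl group, along with a 1.1-fold higher number from compound 1 to compound 2 (0.03 log units; within the scatter). All of them stay within the scatter, so no step beyond the scatter is expected in this assay. The expected change is a 1.3-fold lower number from compound 3 to compound 4 (0.10 log units; within the scatter). Compound 4 is estimated at 220 nM, with an expected range from 90 nM to 550 nM.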

Compound 4, half-maximal inhibitory concentration: 250 nM
Compound 4: middle estimate off by 1.1-fold (0.06 log units), on the low side; the range from low to high includes it.
By their numbers in this assay, from the lowest: compounds 1, 2, 4 and 3 (each within the scatter of the next).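

Swapping 3-methoxyphenyl for 4-methoxyphenyl on the aromatic nitrogen gives a 1.1-fold lower number from compound 3 to compound 4 (0.05 log units; within the scatter) in this assay, so the new compound cannot be told apart from its closest neighbour. The same holds for the other two aryl groups, with a 1.7-fold higher number from compound 2 to compound 4 (0.22 log units; within the scatter) and a 1.8-fold higher number from compound 1 to compound 4 (0.25 log units; within the scatter) as the steps. Nothing shown explains these results.

From the compounds shown here alone, it stays open whether an amine or a carboxylic acid on the phenyl ring, or a longer chain in place of that ring, would give a step beyond the scatter.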